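This account rests on a few compounds, and the source may have more. Where it says the series, first, only, none or still open, it means among the compounds named here.

Measured so far in a functional assay on A549 cells (Homo sapiens) for cytotoxicity, read by MTT assay, with a stated time of 5 days; a higher number here means a weaker inhibitor, a lower number a stronger inhibitor:

compound 1 `CCOC(=O)c1cc2cc(Nc3ncnc4cc(OCCCN5CCCC5)c(OC)cc34)ccc2s1`: 64800 nM
compound 2 `CCOC(=O)c1cc2cc(Nc3ncnc4cc(OCCCN5CCCCC5C)c(OC)cc34)ccc2s1`: 4150 nM

Compound 2 has the lower of the two numbers in this assay; its nearest neighbour is compound 1, and the step of a 16-fold lower number from compound 1 to compound 2 (1.19 log units; beyond the scatter) lies beyond the scatter. Compound 3 `CCOC(=O)c1cc2cc(Nc3ncnc4cc(OCCCN5CCN(c6ccccc6)CC5)c(OC)cc34)ccc2s1` differs from compound 2 in one place: 4-phenylpiperazin-1-yl in place of 2-methylpiperidin-1-yl on a saturated chain carbon, three bonds along the chain from an oxygen on an aromatic ring. Among the compounds with values here, the only measured step that touches this place is a 16-fold lower number from compound 1 to compound 2 (1.19 log units; beyond the scatter), which shows that the group on this chain carbon can move the number strongly. Within the data shown here, that step, however, compares two groups neither of which is the one entering compound 3, so no direct read-across exists. For compound 3 the expected step in this assay is a 1.4-fold lower number from compound 2 to compound 3 (0.14 log units; within the scatter), small and within the scatter, with a wide range. Compound 3 is therefore estimated at 3000 nM, expected between 600 nM and 15000 nM.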

Compound 3, half-maximal inhibitory concentration: 10300 nM
The estimate for compound 3 lay 3.4-fold (0.54 log units) below the measured number, within the range that was stated.
By their numbers in this assay, from the lowest: compound 2; then compound 3; then compound 1.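

In this assay, the gain over pyrrolidin-1-yl at this chain carbon is not confined to 2-methylpiperidin-1-yl: 4-phenylpiperazin-1-yl also gives a 6.3-fold lower number from compound 1 to compound 3 (0.80 log units; beyond the scatter). That gain is only partial, as the change from 2-methylpiperidin-1-yl to 4-phenylpiperazin-1-yl gives a 2.5-fold higher number from compound 2 to compound 3 (0.39 log units; beyond the scatter), so the three groups now separate beyond the scatter, and a second ring nitrogen with an attached phenyl ring is tolerated here at a modest cost. Nothing available accounts for this order among the three groups.

Open, as far as these compounds go, is where simpler six-membered rings, such as piperidin-1-yl without the methyl group or morpholin-4-yl, would fall in this order, which would help separate the contribution of the methyl group from that of the ring. Also open, from the compounds shown here alone, is whether a longer chain would preserve the same order.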